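The source may hold more compounds than are shown below. What is called first, only, known or untested is meant among the compounds shown, and "the series" means these compounds.

Measured in a functional assay on MDA-MB-231 cells (Homo sapiens) for inhibition, read by MTT assay, with a stated time of 72 h; a higher number here means a weaker inhibitor, a lower number a stronger inhibitor:

- Compound 1 `CC(C)COC(=O)NCCOc1ccc(Cl)cc1C(=O)N[C@H](C(=O)Nc1ccc([N+](=O)[O-])cc1Cl)C(C)C`: 4900 nM
- Compound 2 `CC(C)C[C@H](NC(=O)c1cc(Cl)ccc1OCCNC(=O)OC(C)(C)C)C(=O)Nc1ccc([N+](=O)[O-])cc1Cl`: > 10000 nM, a limit of the assay and not a number
- Compound 3 `CC(C)C[C@H](NC(=O)c1cc(Cl)ccc1OCCN)C(=O)Nc1ccc([N+](=O)[O-])cc1Cl`: > 10000 nM, also a limit of the assay and not a number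

Compound 1 is the only one of the three with a numerical reading. Compound 3 stands at the limit of > 10000 nM in this assay, at which 2 of the 3 values shown sit, so its true position is not known. Compound 4 `CSCC[C@H](NC(=O)c1cc(Cl)ccc1OCCN)C(=O)Nc1ccc([N+](=O)[O-])cc1Cl` differs from compound 3 by one change, (methylsulfanyl)methyl in place of isopropyl on a saturated chain carbon, two bonds along the chain from an amide-type nitrogen and a carbonyl carbon.

For the measured compounds named here, the one measured step that reaches compound 3 is a step that the two limits leave unreadable from compound 2 to compound 3. It is a change at a different place in the molecule, and it has no readable size to carry over. No measured step among these compounds makes the exchange found in compound 4. The expectation therefore starts from compound 3, whose > 10000 nM is a limit.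

The expected step, a step that the limit leaves unreadable from compound 3 to compound 4, is none beyond the scatter, and no direction can be favoured. A reading that again gives only a limit is considered likely. For compound 4 the estimated value is 11000 nM, with an expected range of 4500 nM to 25000 nM.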

Compound 4, half-maximal inhibitory concentration: > 10000 nM
Compound 4 was reported as a limit (the forecaster's own chance of this, stated with the estimate: 65%); the middle value lies beyond the limit too.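

In this assay compound 4 gives > 10000 nM as a limit of the assay and not a number. Compound 3 is also held at a limit, so no step can be read between compound 3 and compound 4. Where these two compounds truly lie, and whether (methylsulfanyl)methyl in place of isopropyl changes inhibition at all, stays open: the limit of > 10000 nM in this assay, at which 3 of the 4 values shown sit.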